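From cyclopropylmethyl to (pyridin-2-yl)methyl in a stability assay

The compounds below may be only part of what the source reports. "The series", "measured", "known", "first", "only" and "open" are said of these compounds alone.

Measured in an in vitro ADME assay on microsomes from liver (Homo sapiens) for metabolic stability, tested at 5 uM; a higher number here means that the compound lasts longer, a lower number that the compound disappears faster:
Compound 1 `CCC(C)CCn1nc(-c2cccs2)c(O)c(C2=NS(=O)(=O)c3cc(NS(C)(=O)=O)ccc3N2)c1=O`: > 1 h (a limit)
Compound 2 `CCCC(C)n1nc(-c2cccs2)c(O)c(C2=NS(=O)(=O)c3cc(NS(C)(=O)=O)ccc3N2)c1=O`: > 1 h (a limit)
Compound 3 `CS(=O)(=O)Nc1ccc2c(c1)S(=O)(=O)N=C(c1c(O)c(-c3cccs3)nn(CC3CC3)c1=O)N2`: > 1 h (a limit)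

Compound 3 stands at > 1 h, which is a limit and not a number. Within the data shown here, the other two compounds offer no firmer reference, and the whole series so far rests on one point: the limit of > 1 h in this assay, at which 3 of the 3 values shown sit.

Compound 4 `CS(=O)(=O)Nc1ccc2c(c1)S(=O)(=O)N=C(c1c(O)c(-c3cccs3)nn(Cc3ccccn3)c1=O)N2` keeps the core of compound 3 and carries pyridin-2-yl in place of cyclopropyl on a saturated chain carbon bound to an aromatic nitrogen. Read one bond further out, this is cyclopropylmethyl to (pyridin-2-yl)methyl.

Among the measured compounds shown here, two measured steps bear on this change, as both alter the group on the same aromatic nitrogen. One is a step that the two limits leave unreadable from compound 1 to compound 3. The other is a step that the two limits leave unreadable from compound 2 to compound 3. Neither gives a size, and neither involves an aromatic ring in that group, so they offer no direction for compound 4.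

No step beyond the scatter is therefore expected in this assay, and the estimated step reads a step that the limit leaves unreadable from compound 3 to compound 4. A further limit is the likeliest report for compound 4. For compound 4 the expected value is 1.5 h, with an estimated range from 0.6 h to 4 h.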

Compound 4, half-life: > 1 h
Compound 4: no number, only a limit; the forecaster's own chance of this, stated with the estimate: 70%; the middle value does not contradict the limit.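

In this assay compound 4 gives > 1 h as a limit, not a number. Among these compounds, no step from compound 1, compound 2 or compound 3 to compound 4 can be read, and the series still rests on one point: the limit of > 1 h in this assay, at which 4 of the 4 values shown sit.

The compounds shown leave open how long any of the four actually lasts, and whether (pyridin-2-yl)methyl and cyclopropylmethyl differ at all.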